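Carboxyphenyl ether variation on a dimethyl core

A few compounds are considered here, and "the series" means these few. Any claim that something is new, unique, unknown or untested is made for them only; others in the source may bear on it.

Measured compounds:
compound 1 `Cc1c(OCCCCOc2cccc(C(=O)O)c2)ccc(C(=O)CC(C)C)c1C` 12.1%
compound 2 `CCC(=O)c1ccc(OCCCCOc2ccc(F)c(C(=O)O)c2)c(C)c1O` 66.6%
compound 3 `Cc1c(OCCCCOc2cccc(C(=O)O)c2)ccc(C(=O)CC(C)C)c1O` 84.5%

In an assay on HEK293 cells for positive allosteric modulation of metabotropic glutamate receptor 2 (Rattus norvegicus), read by thallium flux, with a stated time of 2.5 min (a higher number here means a larger maximal response, a lower number a smaller maximal response), compound 1 gives the lowest of the three numbers shown; compound 2 sits closer to it and compound 3 furthest away, both beyond the scatter. For the measured compounds named here, the one single-place step measured, a number 72.4 percentage points higher from compound 1 to compound 3 (beyond the scatter), is large and lies on the core of compound 1, not on the ether-linked aryl acid.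

Compound 4 `Cc1c(OCCCCOc2ccc(C(=O)O)c(Cl)c2)ccc(C(=O)CC(C)C)c1C` keeps the core of compound 1 and changes only that aryl acid: 4-carboxy-3-chlorophenyl in place of 3-carboxyphenyl on an oxygen on a saturated carbon

Going by the values given here, no measured step touches this position. Compound 2 and compound 3 differ at the aryl acid as well as at the core and at the ketone chain, so their two values only show that a halogen-bearing carboxyphenyl can still sit with a mid to high maximal response when the core carries hydroxy. With the core of compound 1 retained, the maximal response is expected to stay near the low end, a step of a number 5.9 percentage points higher from compound 1 to compound 4 (within the scatter) that is expected to be within or only just beyond the scatter. Compound 4 is therefore estimated at 18%, in the range 5% to 40%.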

Compound 4, largest response reached (reported as percent of maximum), in percent of the reference or control that the assay uses: 33.1%
Estimate against measurement, compound 4: 15.1 percentage points below; the measured number falls inside the stated range.
By their numbers in this assay, from the lowest: compound 1; then compound 4; then compound 2; then compound 3.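

In this assay the ether-linked aryl acid proves to be a position that can move the maximal response on the core of compound 1: 4-carboxy-3-chlorophenyl in place of 3-carboxyphenyl gives a number 21 percentage points higher from compound 1 to compound 4 (beyond the scatter). This step is modest, while a number 72.4 percentage points higher from compound 1 to compound 3 (beyond the scatter) at the core is large, so the low end of the series is not fixed by the core alone. No supporting measurement accompanies the step, and the result stands without an explanation.

The two aryl acids differ both in where the carboxyl group sits and in the chlorine, and these two changes cannot be separated here. Open, from the compounds shown here alone, are how 4-carboxy-3-chlorophenyl reads on the hydroxy-bearing core of compound 3, and whether 4-carboxyphenyl without chlorine, or a tetrazole in place of the carboxylic acid, gives a similar step.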